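A few compounds are considered here, and "the series" means these few. Any claim that something is new, unique, unknown or untested is made for them only; others in the source may bear on it.

Measured compounds and their maximal responses:

Compound 1, `CCc1nnc2c(C#N)c(N3CCC(c4ccccc4)CC3)ccn12`, gives 247% in a functional assay on CHO cells for positive allosteric modulation of metabotropic glutamate receptor 2 (Homo sapiens), read by GTPgammaS binding, with a stated time of 30 min; on this read-out lower numbers stand for smaller maximal responses and higher numbers for larger maximal responses.
Compound 2, `N#Cc1c(N2CCC(c3ccccc3)CC2)ccn2c(CC3CC3)nnc12`, gives 278% in this assay.
Compound 3, `Clc1c(N2CCC(c3ccccc3)CC2)ccn2c(CC3CC3)nnc12`, gives 343% in this assay.

The three measured compounds share a core and differ at two places. Compound 2 and compound 3 differ by one change, (chloro in place of cyano on an aromatic carbon), and this step is a number 65 percentage points higher from compound 2 to compound 3 (beyond the scatter). Compound 2 and compound 1 differ by another single change, (methyl in place of cyclopropyl on a saturated chain carbon bound to an aromatic carbon), and here the step is a number 31 percentage points lower from compound 2 to compound 1 (beyond the scatter). Compound 3 stands highest of the three in this assay, and its gaps to compound 2 and to compound 1 are both beyond the scatter.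

Compound 4, `CCc1nnc2c(Cl)c(N3CCC(c4ccccc4)CC3)ccn12`, has not yet been measured in this assay. For the measured compounds named here, it differs from compound 3 by methyl in place of cyclopropyl on a saturated chain carbon bound to an aromatic carbon, which is the same change, at the same place, as the one from compound 2 to compound 1. Among the compounds shown, this change occurs twice, and only one occurrence is measured. On that single occurrence alone, the step from compound 3 to compound 4 is expected to be of similar size, that is a number 31 percentage points lower from compound 3 to compound 4 (beyond the scatter), because the measured occurrence gave a number 31 percentage points lower from compound 2 to compound 1 (beyond the scatter). Compound 4 is therefore expected to give about 312% in this assay, most likely between 265% and 360%, though a single precedent is a thin basis.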

Compound 4, largest response reached (Emax), in percent of the reference or control that the assay uses: 262%
Beside the measured number, compound 4's estimate is 50 percentage points above it; the measured number lies below the stated range.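

In this assay, methyl in place of cyclopropyl lowered the maximal response on both cores, and the new step, a number 81 percentage points lower from compound 3 to compound 4 (beyond the scatter), keeps the direction of the earlier one but not its size: the same change on two cores in this assay, a number 31 percentage points lower (beyond the scatter) from compound 2 to compound 1 and a number 81 percentage points lower (beyond the scatter) from compound 3 to compound 4, 50 percentage points apart, beyond the scatter of two such steps. The change of chloro in place of cyano also kept its direction, with the step now a number 15 percentage points higher from compound 1 to compound 4 (beyond the scatter), and its size did not carry over either: the same change on two cores in this assay, a number 65 percentage points higher (beyond the scatter) from compound 2 to compound 3 and a number 15 percentage points higher (beyond the scatter) from compound 1 to compound 4, 50 percentage points apart, beyond the scatter of two such steps. Across these four compounds, the direction of each change held while its size depended on the group at the other place, so the two changes do not add up independently; this does not show why they interact, and a single pair of steps for each change gives no rule for any other core.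

The compounds shown leave open whether the same behaviour would appear with other groups at these two places, such as a longer chain in place of ethyl, or bromo or an amine in place of chloro and cyano. They also leave open whether a read-out other than the maximal response would show the same dependence between the two places.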